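Two Weakly Active Esters and a Doubly Methylated Successor

This account rests on a few compounds, and the source may have more. Where it says the series, first, only, none or still open, it means among the compounds named here.

Measured so far:
Compound 1, `COC(=O)[C@@]1(C)CCC=C2[C@@H]1CC[C@@H](C)[C@]2(C)Cc1c[nH]c2ccc(C)cc12`: 18000 nM
Compound 2, `COC(=O)[C@@]1(C)CCC=C2[C@@H]1CC[C@@H](C)[C@]2(C)Cc1c(C)[nH]c2ccccc12`: 14000 nM

Both values come from a functional assay on HBL-100 cells (Homo sapiens) for inhibition, read by sulforhodamine B assay, with a stated time of 48 h; on this read-out lower numbers stand for stronger inhibition of growth and higher numbers for weaker inhibition of growth. Compound 1 and compound 2 share the same core and differ only in where a single methyl sits on the two-ring aromatic part. Compound 2 gives the smaller of the two numbers, but the gap to compound 1 is within the usual scatter, so the two cannot be told apart on this evidence, and neither can be called the more active.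

Compound 3, `COC(=O)[C@@]1(C)CCC=C2[C@@H]1CC[C@@H](C)[C@]2(C)Cc1c(C)[nH]c2ccc(C)cc12`, carries both methyls at once. Relative to compound 2 the change is methyl in place of hydrogen on an aromatic carbon, on an aromatic carbon of the six-membered aromatic ring of carbon only, part of a fused system of two rings. Among the measured compounds shown here, no step between measured compounds isolates this particular change, so there is no measured guide to its size. Since compound 1 and compound 2 sit so close together, the added methyl is expected to move compound 3 by no more than the scatter in this assay, giving an expected step of no change at the digits printed from compound 2 to compound 3 (within the scatter). Compound 3 is therefore estimated at 14000 nM, within a range from 7000 nM to 30000 nM.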

Compound 3, concentration for 50% growth inhibition: 25000 nM
Beside the measured number, compound 3's estimate is 1.8-fold (0.25 log units) below it; the range from low to high includes it.
By their numbers in this assay, from the lowest: compounds 2, 1 and 3 (each within the scatter of the next).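

In this assay, the methyl on the six-membered aromatic ring, meta to a fused ring and para to a fused ring, now has a measured step of its own: a 1.8-fold higher number from compound 2 to compound 3 (0.25 log units; within the scatter), which lies within the scatter, so this addition gives no readable shift at this position. The other methyl, also a methyl in place of hydrogen on an aromatic carbon, gives a 1.4-fold higher number from compound 1 to compound 3 (0.14 log units; within the scatter), again within the scatter. Where the earlier pair could only compare two compounds that each carry a single methyl, these steps show that carrying both methyls at once yields no difference that can be read in this assay, and no further measurement is available to explain that result.

The compounds shown leave open whether a group other than methyl on this ring, such as a chlorine atom, a methoxy group or an amine, would shift the number beyond the scatter. They also leave open whether a carboxylic acid in place of the methyl ester on the shared core would do so.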